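Lactam ring size and lipophilicity across two different cores

A few compounds are considered here, and "the series" means these few. Any claim that something is new, unique, unknown or untested is made for them only; others in the source may bear on it.

Compound 1 `C[C@]1(CS(=O)(=O)N2CC=C(C#Cc3cccc(N4CCCC4=O)c3)CC2)NC(=O)NC1=O` and compound 2 `C[C@]1(CS(=O)(=O)N2CC=C(C#Cc3cccc(N4CCCCC4=O)c3)CC2)NC(=O)NC1=O` share one core, and compound 3 `O=C1CCCN1c1cnc(NCc2c(F)ccc3c2CCO3)c2cn[nH]c(=O)c12` and compound 4 `O=C1CCCCN1c1cnc(NCc2c(F)ccc3c2CCO3)c2cn[nH]c(=O)c12` share another; the difference between the two cores is not broken down here. In a physicochemical assay for lipophilicity, at pH 7.4 (a lower number here means a more polar compound, a higher number a more lipophilic compound), compound 1 gives 1.5, compound 2 gives 1 and compound 3 gives 1.8. The change from compound 1 to compound 2 is 2-oxopiperidin-1-yl in place of 2-oxopyrrolidin-1-yl on an aromatic carbon, and it made a number 0.50 log units lower from compound 1 to compound 2 (beyond the scatter). The same kind of change is made from compound 3 to compound 4: 2-oxopiperidin-1-yl in place of 2-oxopyrrolidin-1-yl on an aromatic carbon. The place differs: in compound 1 the group sits on a six-membered aromatic ring of carbon only, meta to a large group, whereas in compound 3 it sits on a six-membered aromatic ring with 1 nitrogen, part of a fused or bridged system of two rings, ortho to a fused ring, two atoms from the ring nitrogen, meta to a fused ring and para to a large group. Compound 4 is not yet measured in this assay. For the measured compounds named here, the expected step is a number 0.50 log units lower from compound 3 to compound 4 (beyond the scatter), because the same kind of change gave a number 0.50 log units lower from compound 1 to compound 2 (beyond the scatter) in the one measured pair. Compound 4 is estimated at 1.3 in this assay, with a likely range from 0.9 to 1.7.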

Compound 4, distribution coefficient: 1.9
For compound 4 the middle estimate is 0.60 log units below the measured one, outside the stated range (above it).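

The swap of 2-oxopyrrolidin-1-yl for 2-oxopiperidin-1-yl gave a number 0.50 log units lower from compound 1 to compound 2 (beyond the scatter) in this assay on one core, but the same swap gives a number 0.10 log units higher from compound 3 to compound 4 (within the scatter) on the other core, so the step seen in the first pair did not carry over to the second. In these two pairs, then, one measured step was not a safe guide to the same change on a different core, although two pairs are too few to set a rule for the rest of the series. No measurement shown gives a reason why the two pairs disagree.

The compounds shown leave open whether the disagreement comes from the aromatic ring carrying the lactam or from other parts of the two cores, and how the same swap would behave on a third core. They also leave open what this assay would read on either core with a carboxylic acid or a simple amine in place of the lactam.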